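The source may hold more compounds than are shown below. What is called first, only, known or untested is meant among the compounds shown, and "the series" means these compounds.

Measured compounds:
- Compound 1, `COc1cc2ccc(=O)oc2cc1OC(=O)c1c(C)noc1-c1ccccc1`: in a functional assay on HCT-116 cells (Homo sapiens) for inhibition, read by MTT assay, with a stated time of 48 h (a lower number here means a stronger inhibitor, a higher number a weaker inhibitor), compound 1 gives 22700 nM.
- Compound 2, `COc1cc2ccc(=O)oc2cc1OC(=O)c1c(-c2ccc(Cl)cc2)n[nH]c1C`: in this assay compound 2 gives 13800 nM.

Compound 2 has the lower of the two numbers, but its value and that of compound 1 lie within the usual scatter of each other, so the two cannot be told apart on these data. Compound 3, `COc1cc2ccc(=O)oc2cc1OC(=O)c1c(-c2ccccc2F)n[nH]c1C`, has not yet been measured. It differs from compound 2 in one place: 2-fluorophenyl in place of 4-chlorophenyl on an aromatic carbon. In words, a 2-fluorophenyl stands in place of the 4-chlorophenyl on an aromatic carbon of the five-membered aromatic ring with two nitrogens, the carbon next to the ring nitrogen and next to the ring atom that bears the large group.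

Within the data shown here, no pair of measured compounds shows this exchange, so the size of the step is not known from the data. Among the measured compounds shown here, with only two measured compounds, both close together, the change from compound 2 to compound 3 is expected to stay within the scatter, with no clear direction. Compound 3 is therefore expected to give about 15000 nM, with a range from 6000 nM to 40000 nM. This estimate means a step of a 1.1-fold higher number from compound 2 to compound 3 (0.04 log units; within the scatter), expected to be no larger than the scatter.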

Compound 3, half-maximal inhibitory concentration: > 25000 nM
Compound 3: only a limit was reported (the forecaster's own chance of this, stated with the estimate: 10%); middle value at least 1.6-fold (0.22 log units) away from the limit.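

In this assay compound 3 gives > 25000 nM, which is a limit of the assay and not a number. Placing 2-fluorophenyl in place of 4-chlorophenyl on this aromatic carbon gives the first step at this position, an at least 1.8-fold higher number from compound 2 to compound 3 (0.25 log units; that floor lies within the scatter), so the exchange brings no lower number, but the data cannot show whether it truly weakens inhibition. The size of any loss stays unresolved, since the printed figure is only a floor and the real value of compound 3 could lie anywhere past it: the limit of > 25000 nM in this assay, at which 1 of the 3 values shown sits.

Both the halogen and its place on the phenyl ring change in this one step, so the compounds shown cannot say which of the two matters, and a 4-fluorophenyl or a 2-chlorophenyl on this carbon would separate them. Going by these compounds, how an amine or a carboxylic acid on that phenyl ring would read in this assay also remains open.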